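Thiophene in Place of Methylpiperazine on the Shared Core

The source may hold more compounds than are shown below. What is called first, only, known or untested is meant among the compounds shown, and "the series" means these compounds.

Measured so far in a functional assay on the whole organism (liver, strain NMRI) for inhibition, with Mus musculus as the target, with a stated time of 3 h, at a dose of 3 mg/kg by the oral route; a higher number here means more inhibition at the dose given (going by the name of the read-out), a lower number less inhibition:
- compound 1, `O=[N+]([O-])c1cc(-c2nc(-c3ccccc3)no2)cc(O)c1O`: 20.6%
- compound 2, `O=[N+]([O-])c1cc(-c2nc(-c3ccc(Br)cc3)no2)cc(O)c1O`: 12.7%
- compound 3, `CN1CCN(c2noc(-c3cc(O)c(O)c([N+](=O)[O-])c3)n2)CC1`: 56.8%

Compound 3 stands highest of the three, with compound 1 nearest and compound 2 furthest, both gaps beyond the scatter. Compound 4, `O=[N+]([O-])c1cc(-c2nc(-c3cccs3)no2)cc(O)c1O`, is not yet measured; it differs from compound 3 in one place: thiophen-2-yl in place of 4-methylpiperazin-1-yl on an aromatic carbon.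

Going by the values given here, two steps bear on this: a number 36.2 percentage points higher from compound 1 to compound 3 (beyond the scatter) and a number 44.1 percentage points higher from compound 2 to compound 3 (beyond the scatter), each a large rise when the 4-methylpiperazin-1-yl entered in place of a six-membered aromatic group. Compound 4 reverses that direction with another aromatic group, and a number 7.9 percentage points lower from compound 1 to compound 2 (within the scatter) suggests such aromatic groups give similar numbers. A large drop is therefore expected, a number 34.8 percentage points lower from compound 3 to compound 4 (beyond the scatter). Compound 4 is estimated at 22%, within 5% to 45%.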

Compound 4, a percentage reported as inhibition, in the whole organism at one dose (the size of the read-out at that dose, not a potency): 29.6%
Compound 4: middle estimate off by 7.6 percentage points, on the low side, within the range that was stated.
By their numbers in this assay, from the lowest: compounds 2, 1 and 4 (each within the scatter of the next, the first and the last beyond it); then compound 3.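

In this assay, a five-membered aromatic ring does not keep what the 4-methylpiperazin-1-yl group gives: a number 27.2 percentage points lower from compound 3 to compound 4 (beyond the scatter). Among the aromatic groups the picture splits, with a number 9 percentage points higher from compound 1 to compound 4 (within the scatter), but a number 16.9 percentage points higher from compound 2 to compound 4 (beyond the scatter), so thiophen-2-yl can be told apart from 4-bromophenyl but not from phenyl. Nothing measured here gives a reason for these differences.

The compounds shown leave open whether the high number of compound 3 depends on the whole 4-methylpiperazin-1-yl ring or only on its nitrogen atoms. A morpholin-4-yl ring or an open-chain dimethylamino group at this place could help separate the two.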